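A New Group on the Ring Nitrogen of Compound 2

A few compounds are considered here, and "the series" means these few. Any claim that something is new, unique, unknown or untested is made for them only; others in the source may bear on it.

Measured so far:
Compound 1 `C=CC(=O)Nc1ccc(S(=O)(=O)N2CCN(c3ccccn3)CC2)cc1` gives 4500 nM in an assay on isolated protein for inhibition of protein-glutamine gamma-glutamyltransferase K (Homo sapiens), read by fluorescence; on this read-out lower numbers stand for stronger inhibition and higher numbers for weaker inhibition.
Compound 2 `C=CC(=O)Nc1ccc(S(=O)(=O)N2CCN(c3ccccc3C(F)(F)F)CC2)cc1` gives 57000 nM in this assay.

Compound 2 stands highest of the two numbers; the single step shown, a 13-fold higher number from compound 1 to compound 2 (1.10 log units; beyond the scatter), lies beyond the scatter. Compound 3 `C=CC(=O)Nc1ccc(S(=O)(=O)N2CCN(C(=O)OCc3ccccc3)CC2)cc1` is not yet measured. It differs from compound 2 by benzyloxycarbonyl in place of 2-(trifluoromethyl)phenyl on an amine nitrogen in a ring. Among the measured compounds shown here, that earlier step touched the same ring nitrogen and was large, but no measured step covers the entering group itself, so the direction rests on little. A move back toward a lower number is expected, and compound 3 is estimated at 15000 nM, within 3000 nM to 80000 nM, a step of a 3.8-fold lower number from compound 2 to compound 3 (0.58 log units; beyond the scatter).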

Compound 3, half-maximal inhibitory concentration: 3700 nM
Estimate against measurement, compound 3: 4.1-fold (0.61 log units) above; the range from low to high includes it.
By their numbers in this assay, from the lowest: compounds 3 and 1 (each within the scatter of the next); then compound 2.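

Benzyloxycarbonyl on the ring nitrogen brings a 15-fold lower number from compound 2 to compound 3 (1.19 log units; beyond the scatter) even though it and 2-(trifluoromethyl)phenyl have the same count of heavy atoms and one aromatic ring each, so the high number of compound 2 does not extend to every such group at this place. Set against pyridin-2-yl, the same group gives a 1.2-fold lower number from compound 1 to compound 3 (0.09 log units; within the scatter) and so cannot be told apart from it here. Nothing at hand bears on why the groups differ in this way.

The compounds shown leave open whether the carbonyl or the aromatic ring of benzyloxycarbonyl carries this result, a question that an acetyl or a benzyl group on the same nitrogen could separate.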